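Cyclohexyl for 4-methoxyphenyl on the shared adenosine-type core

This account rests on a few compounds, and the source may have more. Where it says the series, first, only, none or still open, it means among the compounds named here.

This account follows a single change from compound 1 `COc1ccc(Nc2ncnc3c2ncn3C2O[C@H](C(=O)O)[C@@H](O)[C@H]2O)cc1` to compound 4 `O=C(O)[C@H]1OC(n2cnc3c(NC4CCCCC4)ncnc32)[C@H](O)[C@@H]1O`. In an assay with adenosine receptor A1 (Rattus norvegicus) as the target (a higher number here means a weaker inhibitor, a lower number a stronger inhibitor), compound 1 gives 1 nM, the lowest of the three numbers at hand. Compound 3 `CCNC(=O)[C@H]1OC(n2cnc3c(Nc4ccc(OC)cc4)ncnc32)[C@H](O)[C@@H]1O` gives 4.6 nM in this assay, and compound 2 `C=CCNC(=O)[C@H]1OC(n2cnc3c(NC(CC)CC)ncnc32)[C@H](O)[C@@H]1O` gives 17 nM.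

The change to compound 4 is cyclohexyl in place of 4-methoxyphenyl on a nitrogen on an aromatic ring. Among the measured compounds shown here, no measured step matches it: the only step with one change, a 4.6-fold higher number from compound 1 to compound 3 (0.66 log units; beyond the scatter), concerns the carbonyl carbon and not the nitrogen on the aromatic ring, so it says nothing direct about this replacement. For the measured compounds named here, compound 2 carries an open-chain group on that nitrogen and also another group on the carbonyl, so its value against that of compound 3 mixes two changes and is no clean guide; it shows only that an alkyl group there can still give a strong inhibitor.

Going by the values given here, with no directly relevant step, the expected move is small, and compound 4 is estimated to keep a low number, with a 1.5-fold higher number from compound 1 to compound 4 (0.18 log units; within the scatter) at most a modest shift. Compound 4 is therefore expected to give about 1.5 nM in this assay, within 0.4 nM to 6 nM.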

Compound 4, half-maximal inhibitory concentration: 0.86 nM
Compound 4: the middle estimate sits 1.7-fold (0.24 log units) above what was measured; the measured number falls inside the stated range.
By their numbers in this assay, from the lowest: compounds 4 and 1 (each within the scatter of the next); then compound 3; then compound 2.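

Among the compounds shown here, this is the first clean reading at the nitrogen on an aromatic ring, since the only earlier step concerned the carbonyl carbon. In this assay, the replacement gives a 1.2-fold lower number from compound 1 to compound 4 (0.07 log units; within the scatter), so with hydroxy kept on the carbonyl, the non-aromatic cyclohexyl and the aromatic 4-methoxyphenyl cannot be told apart at this position, and the methoxy oxygen of the group that leaves is not needed to keep the number this low. Nothing in the data at hand accounts for this result, so the step stands as an observation without an explanation.

On these data alone, whether cyclohexyl and 4-methoxyphenyl would also match with ethylamino on the carbonyl stays open, as compound 2 and compound 3 each differ from compound 4 in more than one place. The compounds shown also leave open how far this tolerance extends on that nitrogen, for instance to an unsubstituted phenyl, a cyclopentyl, a longer open chain or a ring carrying an amine or a carboxylic acid.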